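The compounds below may be only part of what the source reports. "The series", "measured", "known", "first", "only" and "open" are said of these compounds alone.

Working notes on the series. In a functional assay on A549 cells (Homo sapiens) for inhibition, read by sulforhodamine B assay, with a stated time of 48 h (on this read-out higher numbers stand for weaker inhibition and lower numbers for stronger inhibition), compound 1 (`O=c1c([C@@H]2C[C@H](c3ccccc3)ON2c2ccccc2)coc2ccc(Br)cc12`) gives 51000 nM and compound 2 (`CCO[C@H]1C[C@@H](c2coc3ccc(C)cc3c2=O)N(c2ccccc2)O1`) gives 20700 nM. Compound 2 therefore holds the lower of the two numbers and is the stronger inhibitor of the pair, and the gap between them lies beyond the scatter.

The next compound to be read is compound 3 (`CCO[C@H]1C[C@@H](c2coc3ccc(Br)cc3c2=O)N(c2ccccc2)O1`). It keeps the rest of compound 2 but has bromo in place of methyl on an aromatic carbon, on a six-membered aromatic ring of carbon only that is part of a fused or bridged system of two rings: bromo in place of methyl on an aromatic carbon.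

Within the data shown here, no two measured compounds differ in one place, so the data give no direct measure of this change. In this assay, no step beyond the scatter is the expected outcome, with a slight rise in the number slightly favoured. The expected change is a 1.1-fold higher number from compound 2 to compound 3 (0.05 log units; within the scatter), anchored on compound 2 at 20700 nM. For compound 3 the estimated value is 23000 nM, with an expected range from 9000 nM to 55000 nM.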

Compound 3, half-maximal inhibitory concentration: 21500 nM
For compound 3 the middle estimate is 1.1-fold (0.03 log units) above the measured one; the measured number falls inside the stated range.
By their numbers in this assay, from the lowest: compounds 2 and 3 (each within the scatter of the next); then compound 1.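

In this assay, bromo in place of methyl on an aromatic carbon now has a direct measure (a 1.0-fold higher number from compound 2 to compound 3 (0.02 log units; within the scatter)), so the two groups cannot be told apart at this position while ethoxy sits on the saturated ring carbon. Compound 3 also opens a second one-place comparison with bromo held constant: ethoxy in place of phenyl on a saturated ring carbon gives a step beyond the scatter (a 2.4-fold lower number from compound 1 to compound 3 (0.38 log units; beyond the scatter)), though a modest one, so the only step of that kind among these pairs lies at the saturated ring carbon and not on the aromatic carbon. No evidence on the cause of either step is at hand.

On these data alone, whether bromo and methyl also match with phenyl on the saturated ring carbon stays open, as does the reading for other groups on the aromatic carbon, such as an amine or a carboxylic acid. As far as these compounds go, the ethoxy result rests on a single pair, so it remains unknown how a hydroxyl group or a longer alkoxy chain at the saturated ring carbon would read in this assay.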